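The compounds below may be only part of what the source reports. "The series", "measured", "known", "first", "only" and "open" are said of these compounds alone.

Among the compounds with values here, compound 3 `Cc1cc(NC(=O)Nc2ccc(N(C)C)cc2)c2ccccc2n1` stands at the bottom of the three values so far in an ADME assay for permeability, using PAMPA, at pH 7.4; a higher number here means that the compound crosses the layer faster, a lower number that the compound crosses the layer more slowly: compound 3 gives 2 10^-6 cm/s, whereas compound 1 `CSc1ccc(NC(=O)Nc2cc(C)nc3ccccc23)cc1` gives 473 10^-6 cm/s and compound 2 `Cc1ccc(NC(=O)Nc2cc(C)nc3ccccc23)cc1` gives 669 10^-6 cm/s. The gaps are large in both cases: a 240-fold lower number from compound 1 to compound 3 (2.37 log units; beyond the scatter) and a 330-fold lower number from compound 2 to compound 3 (2.52 log units; beyond the scatter), while between the two higher compounds the difference is small, a 1.4-fold higher number from compound 1 to compound 2 (0.15 log units; within the scatter).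

Compound 4 `Cc1cc(NC(=O)Nc2ccc(N)cc2)c2ccccc2n1` keeps the shared core and changes only the group on the aromatic carbon para to the large group: amino in place of dimethylamino on an aromatic carbon.

Within the data shown here, no measured step shows the move from dimethylamino to amino at this position. The two steps that bear on it, from compound 1 to compound 3 and from compound 2 to compound 3, both show that the dimethylamino compound sits far below the methyl and methylsulfanyl compounds in this assay. Compound 4 carries an amino group that brings a hydrogen-bond donor in place of the dimethylamino, so there is no shown reason to expect a return toward the numbers of compound 1 or compound 2; the expectation is a step of about a 1.3-fold lower number from compound 3 to compound 4 (0.12 log units; within the scatter), within the scatter or modestly lower. Compound 4 is therefore estimated at 1.5 10^-6 cm/s, with a range from 0.4 10^-6 cm/s to 6 10^-6 cm/s.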

Compound 4, apparent permeability: 530 10^-6 cm/s
The estimate for compound 4 lay 350-fold (2.55 log units) below the measured number; the whole stated range lies below it.
By their numbers in this assay, from the lowest: compound 3; then compounds 1, 4 and 2 (each within the scatter of the next).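

In this assay, amino in place of dimethylamino gives a 270-fold higher number from compound 3 to compound 4 (2.42 log units; beyond the scatter) and so shows that a nitrogen on this aromatic carbon does not by itself go with the low number; among the four groups shown, only dimethylamino stands apart. Amino joins methyl and methylsulfanyl, as a 1.3-fold lower number from compound 2 to compound 4 (0.10 log units; within the scatter) and a 1.1-fold higher number from compound 1 to compound 4 (0.05 log units; within the scatter) both lie within the scatter, so these three groups cannot be told apart at this place, even though amino brings a hydrogen-bond donor that dimethylamino lacks. Nothing available explains why dimethylamino alone gives so low a number.

The compounds shown leave open whether the low number belongs to dimethylamino alone or would also appear with methylamino, diethylamino or a pyrrolidine ring on the same aromatic carbon. They also leave open how a carboxylic acid or a methoxy group would read at this place, and whether the same change elsewhere on the shared core would give a step of similar size.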